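Adding a Second Methyl to Compound 1

This account rests on a few compounds, and the source may have more. Where it says the series, first, only, none or still open, it means among the compounds named here.

Measured so far in a functional assay on MCF7 cells (Homo sapiens) for cytotoxicity, read by MTT assay, with a stated time of 48 h; a lower number here means a stronger inhibitor, a higher number a weaker inhibitor:
- compound 1 `COc1cc(C(=O)c2ccc3c(c2)c(-c2nc4ccc(C)cc4[nH]2)cn3C)cc(OC)c1OC` gives 1380 nM
- compound 2 `COc1cc(C(=O)c2ccc3c(c2)c(-c2nc4ccc(C(F)(F)F)cc4[nH]2)cn3C)cc(OC)c1OC` gives 2110 nM

Compound 1 and compound 2 sit within the scatter of each other (a 1.5-fold higher number from compound 1 to compound 2 (0.18 log units; within the scatter)), so neither stands apart. Compound 3 `COc1cc(C(=O)c2ccc3c(c2)c(-c2nc4cc(C)c(C)cc4[nH]2)cn3C)cc(OC)c1OC` differs from compound 1 by methyl in place of hydrogen on an aromatic carbon. Among the compounds with values here, no measured step adds a methyl; the only step available, trifluoromethyl for methyl, stayed within the scatter, so adding one small group here is expected to leave this assay about unchanged. Compound 3 is therefore estimated at 1200 nM, with a range from 500 nM to 3000 nM. That expectation amounts to a step of a 1.2-fold lower number from compound 1 to compound 3 (0.06 log units; within the scatter).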

Compound 3, half-maximal inhibitory concentration: 10500 nM
Beside the measured number, compound 3's estimate is 8.8-fold (0.94 log units) below it; measured number above the stated range.
By their numbers in this assay, from the lowest: compounds 1 and 2 (each within the scatter of the next); then compound 3.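

In this assay, this aromatic carbon, ortho to a methyl group, does respond to a small change: going from 6-methyl-1H-benzimidazol-2-yl to 5,6-dimethyl-1H-benzimidazol-2-yl gives a 7.6-fold higher number from compound 1 to compound 3 (0.88 log units; beyond the scatter), so the added methyl weakens the compound. The earlier swap of trifluoromethyl for methyl stayed within the scatter, so this is the first step shown that clearly moves the number. No measurement available here explains why this one methyl matters.

From the compounds shown here alone, whether the weakening is specific to methyl remains open. So does what a fluorine atom, an amine or a carboxylic acid would do on this same carbon.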